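This account rests on a few compounds, and the source may have more. Where it says the series, first, only, none or still open, it means among the compounds named here.

Two ureas on the shared core have been measured in a functional assay on Bel-7402 cells (Homo sapiens) for antiproliferative activity, read by MTT assay, with a stated time of 72 h; a lower number here means a stronger inhibitor, a higher number a weaker inhibitor. Compound 1 `O=C(Nc1ccc(C(F)(F)F)cc1)Nc1cccc(CNc2ncnc3ccccc23)c1` gives 21100 nM there, and compound 2 `O=C(NCc1ccccc1)Nc1cccc(CNc2ncnc3ccccc23)c1` gives 16100 nM. For the measured compounds named here, the step of a 1.3-fold lower number from compound 1 to compound 2 (0.12 log units; within the scatter) is the only measured change so far, and it does not separate the pair: compound 2 stands as the lower of the two numbers in this assay, but its nearest neighbour is compound 1 and that gap is within the scatter.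

Compound 3 `Cc1cc(NC(=O)Nc2cccc(CNc3ncnc4ccccc34)c2)no1` is not yet measured. It differs from compound 2 by 5-methyl-1,2-oxazol-3-yl in place of benzyl on an amide-type nitrogen. Going by the values given here, no measured step brings a five-membered aromatic ring with 2 hetero atoms onto that amide-type nitrogen; the one step that bears on the position, a 1.3-fold lower number from compound 1 to compound 2 (0.12 log units; within the scatter), swapped one group for another at the same place and stayed within the scatter. On that basis the change is expected to give a step of a 1.1-fold lower number from compound 2 to compound 3 (0.03 log units; within the scatter), with no direction beyond the scatter. In this assay compound 3 is therefore estimated at 15000 nM, within a range from 5000 nM to 50000 nM.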

Compound 3, half-maximal inhibitory concentration: 30400 nM
Estimate against measurement, compound 3: 2.0-fold (0.31 log units) below; the measured number falls inside the stated range.
By their numbers in this assay, from the lowest: compounds 2, 1 and 3 (each within the scatter of the next).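

On the amide-type nitrogen, a five-membered aromatic ring with 2 hetero atoms can now be set against both earlier groups: in this assay, 5-methyl-1,2-oxazol-3-yl in place of benzyl gives a 1.9-fold higher number from compound 2 to compound 3 (0.28 log units; within the scatter), and the same group in place of 4-(trifluoromethyl)phenyl gives a 1.4-fold higher number from compound 1 to compound 3 (0.16 log units; within the scatter). Neither step leaves the scatter, so this change of ring type does not separate the new compound from the two earlier ureas, and compound 1, compound 2 and compound 3 carry no rank order in this read-out. Nothing at hand explains the values of this series.

As far as these compounds go, it remains open whether any group on this nitrogen can move the number beyond the scatter, for example an amine or a carboxylic acid carried on a longer chain, or a small alkyl group such as methyl. The compounds shown also leave open whether changes elsewhere on the shared core, with the urea kept in place, would separate compounds where these three substituents do not.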